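This account rests on a few compounds, and the source may have more. Where it says the series, first, only, none or still open, it means among the compounds named here.

Compound 1 `COc1ccc(Cn2c(-c3ccccc3O)nn(CN3CCN(c4cc5c(cc4F)c(=O)c(C(=O)O)cn5C4CC4)CC3)c2=S)cc1` and compound 2 `COc1ccc(-n2c(-c3cccc(O)c3)nn(CN3CCN(c4cc5c(cc4F)c(=O)c(C(=O)O)cn5C4CC4)CC3)c2=S)cc1` are two close relatives tested in an ADME assay on HEK293 cells (Homo sapiens) for cytotoxicity, read by MTT assay, with a stated time of 72 h; a lower number here means that less compound is needed, a higher number that more compound is needed for the effect. In this assay compound 1 gives 78700 nM, while compound 2 gives 114000 nM. Compound 1 has the smaller of the two numbers, but the gap to compound 2 lies within the usual scatter, so the two cannot be told apart. Compound 3 `COc1ccc(Cn2c(-c3cccc(O)c3)nn(CN3CCN(c4cc5c(cc4F)c(=O)c(C(=O)O)cn5C4CC4)CC3)c2=S)cc1` has not yet been measured. It differs from compound 1 in one place: 3-hydroxyphenyl in place of 2-hydroxyphenyl on an aromatic carbon. Compound 3 thus shares its 3-hydroxyphenyl with compound 2 while keeping the 4-methoxybenzyl group of compound 1. Since compound 2, which gives 114000 nM, sits within the scatter of compound 1, the step of a 1.1-fold higher number from compound 1 to compound 3 (0.06 log units; within the scatter) is expected to stay within the scatter, in no particular direction. Compound 3 is therefore estimated at 90000 nM, with a range from 45000 nM to 180000 nM.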

Compound 3, half-maximal effective concentration: 62900 nM
Compound 3: middle estimate off by 1.4-fold (0.16 log units), on the high side, within the range that was stated.
By their numbers in this assay, from the lowest: compounds 3, 1 and 2 (each within the scatter of the next).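

In this assay, 3-hydroxyphenyl in place of 2-hydroxyphenyl on the aromatic carbon gives a 1.3-fold lower number from compound 1 to compound 3 (0.10 log units; within the scatter) and so stays within the scatter, which shows that this swap, with 4-methoxybenzyl held on the ring nitrogen, does not separate the two compounds. Compounds 1 and 2 differ in two places, so they could not isolate either change. With the 3-hydroxyphenyl held constant, 4-methoxybenzyl in place of 4-methoxyphenyl gives a 1.8-fold lower number from compound 2 to compound 3 (0.26 log units; within the scatter) and also stays within the scatter.

Nothing shown here explains why these numbers lie so close together. Going by these compounds, it also remains open whether an amine in place of the hydroxyl group, or a longer chain in place of the 4-methoxybenzyl group, would take the number beyond the scatter.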